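The compounds below may be only part of what the source reports. "The series", "measured", "known", "first", "only" and "open" are said of these compounds alone.

Measured so far in an assay on isolated protein for inhibition of protein kinase C theta type (Homo sapiens), read by HTRF; a higher number here means a weaker inhibitor, a lower number a stronger inhibitor:
compound 1 `CO[C@@H]1[C@@H](O)[C@@H](O)[C@H]2O[C@]1(C)n1c3ccccc3c3c4c(c5c6ccccc6n2c5c31)C(=O)NC4`: 1010 nM
compound 2 `CO[C@@H]1[C@H](N)C[C@H]2O[C@]1(C)n1c3ccccc3c3c4c(c5c6ccccc6n2c5c31)C(=O)NC4=O`: 36 nM
compound 3 `CO[C@@H]1[C@H](NC=O)C[C@H]2O[C@]1(C)n1c3ccccc3c3c4c(c5c6ccccc6n2c5c31)C(=O)NC4`: only a limit, > 2500 nM

Compound 1 stands as the higher of the two numbers that this assay gives; compound 2 reads far below it, a gap well beyond the usual scatter of repeated runs. Compound 3 returns no number in this assay, only the limit (the limit of > 2500 nM in this assay, at which 1 of the 3 values shown sits), so it cannot be ranked against the other two. Within the data shown here, compounds 2 and 3 each differ from compound 1 in more than one place, so no single step between measured compounds can be isolated, and the values stand on their own.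

Compound 4 `CO[C@@H]1[C@@H](O)[C@@H](O)[C@H]2O[C@]1(C)n1c3ccccc3c3c4c(c5c6ccccc6n2c5c31)C(=O)N[C@H]4O` is the next member to be tested. Relative to compound 1 the change is hydroxy in place of hydrogen on a saturated ring carbon. The shared core, the methoxy group and the two ring hydroxy groups of compound 1 are kept unchanged.

Among the measured compounds shown here, with no comparable single step among the measured compounds, the expectation is a step of modest size, and it is most likely to fall within the scatter of the assay, with the direction open. The estimate for compound 4 in this assay is 700 nM, with a range of 250 nM to 2000 nM, which would mean an expected step of a 1.4-fold lower number from compound 1 to compound 4 (0.16 log units; within the scatter).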

Compound 4, half-maximal inhibitory concentration: 2250 nM
Compound 4: the middle estimate sits 3.2-fold (0.51 log units) below what was measured; the whole stated range lies below it.
By their numbers in this assay, from the lowest: compound 2; then compound 1; then compound 4. At a limit, above all of these: compound 3.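

In this assay the series now has its first step at a single place, hydroxy in place of hydrogen on a saturated ring carbon next to the ring nitrogen, and that step reads a 2.2-fold higher number from compound 1 to compound 4 (0.35 log units; beyond the scatter) in a modest move towards a weaker inhibitor. The earlier compounds shown here could not show this, as each pair among them differs in more than one place; this position now has a direct reading, and adding hydroxy here, with the shared core and the other groups of compound 1 kept unchanged, does not improve inhibition. Nothing in the data shown gives a cause for this step.

As far as these compounds go, whether the upward move belongs to hydroxy alone or to any group on this carbon stays open, since an amine or a fluorine atom here would separate those two readings, and the opposite configuration at this carbon would show whether the orientation of the hydroxy matters. Compound 2 carries a carbonyl on this carbon but also differs from compound 1 elsewhere, so the effect of a carbonyl at this position on its own also remains unread.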